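This account rests on a few compounds, and the source may have more. Where it says the series, first, only, none or still open, it means among the compounds named here.

In a functional assay on Rec1 cells (Homo sapiens) for inhibition, read by luminescence and CellTiter-Glo, with a stated time of 72 h (a higher number here means a weaker inhibitor, a lower number a stronger inhibitor), compound 2 `O=C(CCl)Nc1ccc(Cn2nc(-c3ccc(Oc4ccccc4)cc3)cc2CO)cc1` gives 400 nM. Compound 3 `O=C(CCl)Nc1ccc(Cn2nc(-c3ccc(Oc4ccccc4)cc3)cc2C(=O)O)cc1` gives 4000 nM, a modest difference: a 10-fold higher number from compound 2 to compound 3 (1.00 log units; beyond the scatter), with carboxy in place of hydroxymethyl on an aromatic carbon. Compound 1 `C=CC(=O)Nc1ccc(Cn2nc(-c3ccc(Oc4ccccc4)cc3)cc2C(=O)O)cc1` reads > 60000 nM, which is a limit of the assay and not a number. Compound 4 `C=CC(=O)Nc1ccc(Cn2nc(-c3ccc(Oc4ccccc4)cc3)cc2CO)cc1` differs from compound 2 by vinyl in place of chloromethyl on a carbonyl carbon. The closest measured precedent runs the same exchange in reverse between two carboxy compounds, and it is large: an at least 15-fold lower number from compound 1 to compound 3 (1.17 log units; beyond the scatter). A large rise is therefore expected in this assay. The expected change is a 25-fold higher number from compound 2 to compound 4 (1.40 log units; beyond the scatter). For compound 4 the estimated value is 10000 nM, with an expected range of 2500 nM to 50000 nM.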

Compound 4, half-maximal inhibitory concentration: 3500 nM
For compound 4 the middle estimate is 2.9-fold (0.46 log units) above the measured one, and the stated range covers the measured number.
By their numbers in this assay, from the lowest: compound 2; then compounds 4 and 3 (each within the scatter of the next). At a limit, above all of these: compound 1.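

In this assay, vinyl in place of chloromethyl on a carbonyl carbon now has a measured size on the hydroxymethyl core, an 8.8-fold higher number from compound 2 to compound 4 (0.94 log units; beyond the scatter). Hydroxymethyl in place of carboxy on an aromatic carbon also now appears with the vinylcarbonyl group, an at least 17-fold lower number from compound 1 to compound 4 (1.23 log units; beyond the scatter). Each exchange runs the same way on both cores, but the value of compound 1 is a limit and not a number, so the sizes cannot be compared: the same change on two cores in this assay, an at least 15-fold lower number (1.17 log units; beyond the scatter) from compound 1 to compound 3 and an 8.8-fold lower number (0.94 log units; beyond the scatter) from compound 4 to compound 2; the limit leaves it open whether they differ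

The compounds shown leave open how an amine in place of hydroxymethyl on that aromatic carbon would read. They also leave open what a longer chain than chloromethyl on the carbonyl carbon would give.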